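The source may report more compounds than this note shows. Statements on the series, on what has been measured and on what is new or still open speak of the compounds shown alone.

Three compounds share one core and differ only in the aryl group on the amine nitrogen. Compound 1 `Cc1cc(C(F)(F)F)cc(NC[C@@H]2CC3(CC3)CN2C(=O)c2nc(C)sc2-c2ccccc2)n1` carries a 6-methyl-4-(trifluoromethyl)pyridin-2-yl there, and in a functional assay on CHO cells for antagonist activity at Orexin/Hypocretin receptor type 1 (Homo sapiens), read by FLIPR and calcium flux (a higher number here means a more potent compound, by a factor of ten per unit of this negative logarithm, a lower number a less potent compound), compound 1 gives 7.8. Compound 2 `Cc1cccc(NC[C@@H]2CC3(CC3)CN2C(=O)c2nc(C)sc2-c2ccccc2)n1` carries a 6-methylpyridin-2-yl; in this assay compound 2 gives 7.3. Compound 3 `Cc1cc(C)nc(NC[C@@H]2CC3(CC3)CN2C(=O)c2nc(C)sc2-c2ccccc2)n1` carries a 4,6-dimethylpyrimidin-2-yl, and in this assay compound 3 gives 7.5, the second highest of the three numbers, with compound 2 nearest and compound 1 furthest, both within the scatter. Compound 4 `Cc1nc(C(=O)N2CC3(CC3)C[C@H]2CNc2ccc(Cl)cn2)c(-c2ccccc2)s1` is not yet measured; it differs from compound 3 by 5-chloropyridin-2-yl in place of 4,6-dimethylpyrimidin-2-yl on an amine nitrogen. For the measured compounds named here, two measured steps bear on this. The step of a number 0.20 log units higher from compound 2 to compound 3 (within the scatter) shows that swapping the 6-methylpyridin-2-yl for the 4,6-dimethylpyrimidin-2-yl stayed within the scatter, while a number 0.50 log units lower from compound 1 to compound 2 (beyond the scatter) shows that the group on the pyridine ring can shift the number by a modest amount. Going by the values given here, no measured pair shows a chlorine on this ring, so the direction is open. Compound 4 is therefore expected to land close to compound 3, with no change at the digits printed from compound 3 to compound 4 (within the scatter) expected to remain within the scatter. The estimate for compound 4 in this assay is 7.5, expected to fall between 7 and 8.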

Compound 4, negative logarithm of the antagonist equilibrium constant: 8.3
Estimate against measurement, compound 4: 0.80 log units below; the whole stated range lies below it.
By their numbers in this assay, from the lowest: compounds 2, 3 and 1 (each within the scatter of the next, the first and the last beyond it); then compound 4.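

In this assay the change to 5-chloropyridin-2-yl on the amine nitrogen gives a number 0.80 log units higher from compound 3 to compound 4 (beyond the scatter) and a number 1.00 log units higher from compound 2 to compound 4 (beyond the scatter) and also a number 0.50 log units higher from compound 1 to compound 4 (beyond the scatter) so compound 4 stands above all three earlier compounds. The earlier compounds shown here showed this position responding to the aryl group by a modest amount, and compound 4 shows that the range here reaches further than they revealed. The count of ring hetero atoms does not account for the order on its own, since compound 2 also carries a pyridin-2-yl and the largest of the three new steps starts from it. No measurement given here explains why the chlorine-bearing ring stands apart.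

Compound 4 gains a chlorine and also has no methyl on the ring. The compounds shown cannot separate these two differences. From the compounds shown here alone, whether a bromine, a methyl or a methoxy group in place of that chlorine would hold the number at this level remains open, as does the result for a pyridin-2-yl with no group on the ring at all.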